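Swapping the sulfonyl aryl group in a fluorinated quinoline series

A few compounds are considered here, and "the series" means these few. Any claim that something is new, unique, unknown or untested is made for them only; others in the source may bear on it.

Measured so far:
- compound 1 `Cc1ccc(S(=O)(=O)c2cnc3c(F)cccc3c2-c2ccc(F)cc2)cc1F`: 2.75 mL/min
- compound 2 `O=S(=O)(c1ccc(F)c(F)c1)c1cnc2c(F)cccc2c1-c1ccc(F)cc1`: 0.78 mL/min
- compound 3 `O=S(=O)(c1ccc(F)c(F)c1)c1cnc2c(F)cccc2c1-c1cccc(Cl)c1`: 1.13 mL/min

These values come from an ADME assay on microsomes from liver (Homo sapiens) for metabolic stability, tested at 2.5 uM; on this read-out lower numbers stand for slow clearance and higher numbers for fast clearance. Compound 2 has the lowest number of the three; compound 3 sits within the scatter of it, and compound 1 lies further away, as the step of a 3.5-fold lower number from compound 1 to compound 2 (0.55 log units; beyond the scatter) shows. Compound 4 `N#Cc1cccc(S(=O)(=O)c2cnc3c(F)cccc3c2-c2ccc(F)cc2)c1` differs from compound 2 in one place: 3-cyanophenyl in place of 3,4-difluorophenyl on a sulfonyl sulfur. Among the compounds with values here, no measured step touches the group on the sulfonyl sulfur in this way. The step of a 3.5-fold lower number from compound 1 to compound 2 (0.55 log units; beyond the scatter) concerns the same part of the molecule and was modest, while a 1.4-fold higher number from compound 2 to compound 3 (0.16 log units; within the scatter) stayed within the scatter. An estimate of a 1.5-fold higher number from compound 2 to compound 4 (0.19 log units; within the scatter) is therefore expected, within the scatter. Compound 4 is estimated at 1.2 mL/min, ranging from 0.5 mL/min to 3 mL/min.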

Compound 4, intrinsic clearance in a liver preparation (reported as CLH), per the amount of preparation that the assay uses: 0.19 mL/min
For compound 4 the middle estimate is 6.3-fold (0.80 log units) above the measured one; the measured number lies below the stated range.
By their numbers in this assay, from the lowest: compound 4; then compounds 2 and 3 (each within the scatter of the next); then compound 1.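

The group on the sulfonyl sulfur can move the number in this assay beyond the scatter even when both groups lack a methyl: a 4.1-fold lower number from compound 2 to compound 4 (0.61 log units; beyond the scatter) comes with 3-cyanophenyl in place of 3,4-difluorophenyl. The same group gives the largest change in this set, with a 14-fold lower number from compound 1 to compound 4 (1.16 log units; beyond the scatter) against 3-fluoro-4-methylphenyl. Nothing available explains why the 3-cyanophenyl group gives the lowest number.

Open, from the compounds shown here alone, is whether 4-cyanophenyl, or a phenyl ring carrying an amide or a carboxylic acid, would give a number as low. Also open, going by these compounds, is whether the 3-cyanophenyl change holds alongside the 3-chlorophenyl group of compound 3.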